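A few compounds are considered here, and "the series" means these few. Any claim that something is new, unique, unknown or untested is made for them only; others in the source may bear on it.

Measured in a functional assay on HepG2 cells (Homo sapiens) for cytotoxicity, read by MTT assay, with a stated time of 72 h; on this read-out lower numbers stand for stronger inhibition and higher numbers for weaker inhibition:
Compound 1 `CNC(=O)c1cc(Oc2ccc(C(=O)/C=C/c3cccc(Br)c3)cc2)ccn1`: 2870 nM
Compound 2 `CNC(=O)c1cc(Oc2ccc(C(=O)/C=C/c3ccc([N+](=O)[O-])cc3)cc2)ccn1`: "not determined" (no result reported)
Compound 3 `CNC(=O)c1cc(Oc2ccc(C(=O)/C=C/c3ccc(C#N)cc3)cc2)ccn1`: 5430 nM

Going by the values given here, compound 3, at 5430 nM, lies within the scatter of compound 1, the only other compound with a number. Compound 4 `CNC(=O)c1cc(Oc2ccc(C(=O)/C=C/c3ccccc3)cc2)ccn1` carries hydrogen in place of cyano on an aromatic carbon, para to a large group (hydrogen in place of cyano on an aromatic carbon). Among the compounds with values here, the one measured step, a 1.9-fold higher number from compound 1 to compound 3 (0.28 log units; within the scatter), exchanges one substituted phenyl for another and stays within the scatter. Within the data shown here, no measured step removes the substituent outright, so this evidence is only indirect. In this assay the expected change is therefore none beyond the scatter, an estimated 1.4-fold lower number from compound 3 to compound 4 (0.13 log units; within the scatter). The estimate for compound 4 is 4000 nM, with an expected range from 1500 nM to 11000 nM.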

Compound 4, half-maximal inhibitory concentration: 6640 nM
Compound 4: middle estimate off by 1.7-fold (0.22 log units), on the low side; the range from low to high includes it.
By their numbers in this assay, from the lowest: compounds 1, 3 and 4 (each within the scatter of the next, the first and the last beyond it).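

In this assay, going by these compounds alone, compound 4 shows the ring with no substituent at all for the first time. Within the data shown here, removing the cyano gives a 1.2-fold higher number from compound 3 to compound 4 (0.09 log units; within the scatter) and so leaves the number unchanged within the scatter, whereas hydrogen in place of bromo gives a 2.3-fold higher number from compound 1 to compound 4 (0.36 log units; beyond the scatter) as the first step to pass it, though only modestly. No evidence is available to explain either step. Going by these compounds, it remains open whether an amine or a methoxy group on this ring would move the number beyond the scatter of compound 4. Also open, on these data alone, is whether the contrast between bromo and cyano comes from the group itself or from its place on the ring.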